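Methoxy to hydroxy on compound 2

A few compounds are considered here, and "the series" means these few. Any claim that something is new, unique, unknown or untested is made for them only; others in the source may bear on it.

In an ADME assay on MIA PaCa-2 cells (Homo sapiens) for cytotoxicity, read by MTT assay, with a stated time of 72 h (a higher number here means a weaker inhibitor, a lower number a stronger inhibitor), compound 1 `COc1ccc(C2=C(c3cc(OC)c(OC)c(OC)c3)C(=O)C(OC(C)=O)C2)cc1` gives < 1 ug/mL, which is a limit of the assay. Compound 2 `COc1ccc(C2=C(c3cc(OC)c(OC)c(OC)c3)C(=O)CC2O[SiH2]C(C)(C)C)cc1OC` gives > 100 ug/mL, which is likewise a limit and not a number. Compound 3 `COc1ccc(C2=C(c3cc(OC)c(OC)c(OC)c3)C(=O)CC2O[SiH2]C(C)(C)C)cc1O` differs from compound 2 by hydrogen in place of methyl on an oxygen on an aromatic ring, with hydrogen in place of methyl on an oxygen on an aromatic ring, so that 3,4-dimethoxyphenyl becomes 3-hydroxy-4-methoxyphenyl. Going by the values given here, no measured pair isolates this change, so the expectation is uncertain. The expected step, an at least 10-fold lower number from compound 2 to compound 3 (1.00 log units; beyond the scatter), runs towards stronger inhibition and beyond the scatter. The estimated value for compound 3 is 10 ug/mL, with an expected range from 0.7 ug/mL to 100 ug/mL.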

Compound 3, half-maximal inhibitory concentration: 55 ug/mL
The estimate for compound 3 lay 5.5-fold (0.74 log units) below the measured number; the range from low to high includes it.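

In this assay compound 3 gives 55 ug/mL as a number, so a value can be read for this series with hydroxy on the aromatic ring. Compound 2 gives > 100 ug/mL and this is a limit, not a number. Methoxy to hydroxy can therefore be read only as an at least 1.8-fold lower number from compound 2 to compound 3 (0.25 log units; that floor lies within the scatter) and the true size of the change stays unknown. The compounds shown leave open whether an amine in the same place would give a lower number than hydroxy, and whether a longer chain on that oxygen would give a number at all.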